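The compounds below may be only part of what the source reports. "The series", "measured", "known", "first", "only" and "open" are said of these compounds alone.

Values in a functional assay on PC-3 cells (Homo sapiens) for cytotoxicity, with a stated time of 48 h; on this read-out higher numbers stand for weaker inhibition and lower numbers for stronger inhibition:
- compound 1 `COc1cc(O)c(C(=O)/C=C/c2ccc(F)cc2)c(OC)c1` 13200 nM
- compound 2 `COc1cc(OC)c(C(=O)/C=C/c2ccccc2OC)c(OC)c1` 8100 nM
- compound 3 `COc1cc(OC)c(C(=O)/C=C/c2ccc(Cl)cc2)c(OC)c1` 5800 nM

Compound 3 has the lowest number of the three, but it stands within the scatter of compound 2 and beyond the scatter only from compound 1.

Next is compound 4 `COc1cc(OC)c(C(=O)/C=C/c2ccc(Br)cc2)c(OC)c1` with bromo in place of chloro on an aromatic carbon, para to a large group. Going by the values given here, no measured step exchanges one halogen for another. The nearest evidence is a 1.4-fold lower number from compound 2 to compound 3 (0.15 log units; within the scatter), which brought in the 4-chlorophenyl group. No shift beyond the scatter is therefore expected in this assay. The expected change is a 1.1-fold lower number from compound 3 to compound 4 (0.02 log units; within the scatter). For compound 4 the estimate is 5500 nM, with an expected range of 2800 nM to 11000 nM.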

Compound 4, half-maximal inhibitory concentration: 7100 nM
Estimate against measurement, compound 4: 1.3-fold (0.11 log units) below, and the stated range covers the measured number.
By their numbers in this assay, from the lowest: compounds 3, 4, 2 and 1 (each within the scatter of the next, the first and the last beyond it).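

In this assay, the only halogen exchange shown at this position (a 1.2-fold higher number from compound 3 to compound 4 (0.09 log units; within the scatter)) does not separate bromo from chloro on this aromatic carbon, para to a large group. The 4-bromophenyl group is likewise not separated from the 2-methoxyphenyl group (a 1.1-fold lower number from compound 2 to compound 4 (0.06 log units; within the scatter)), so compound 4 joins compound 2 and compound 3 as one cluster within the scatter. No independent measurement bears on the reason for this result.

Still open, from the compounds shown here alone, is whether an amine or a carboxylic acid at this position would move the number beyond the scatter.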